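A few compounds are considered here, and "the series" means these few. Any claim that something is new, unique, unknown or untested is made for them only; others in the source may bear on it.

Measured in a functional assay on HeLa S3 cells (Homo sapiens) for cytotoxicity, read by MTT assay, with a stated time of 72 h; on this read-out higher numbers stand for weaker inhibition and lower numbers for stronger inhibition:

Compound 1 `C=C(C)[C@H]1C[C@@H](C[C@]23C[C@@H](/C=C/C(C)C)C(C)(C)[C@](C/C=C(\C)CO)(C(=O)C(C(=O)c4ccc(O)c(O)c4)=C2O)C3=O)C1(C)C`: 8000 nM
Compound 2 `CC(=O)[C@H]1C[C@@H](C[C@]23C[C@@H](/C=C/C(C)C)C(C)(C)[C@](CC=C(C)C)(C(=O)C(C(=O)c4ccc(O)c(O)c4)=C2O)C3=O)C1(C)C`: > 10000 nM

Among the measured compounds shown here, the value for compound 1 is a number, so it is the only firm reading in this small set. Compound 2 gives > 10000 nM, which is a limit of the assay and not a number. Compound 2 thus stands at the limit of > 10000 nM in this assay, at which 1 of the 2 values shown sits.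

Compound 3 `C=C(C)[C@H]1C[C@@H](C[C@]23C[C@@H](/C=C/C(C)C)C(C)(C)[C@](CC=C(C)C)(C(=O)C(C(=O)c4ccc(O)c(O)c4)=C2O)C3=O)C1(C)C` has not yet been measured. It departs from compound 2 with 1-methylethenyl in place of acetyl on a saturated ring carbon, in a four-membered non-aromatic ring of carbon only: 1-methylethenyl in place of acetyl on a saturated ring carbon. For the measured compounds named here, no measured pair of compounds shows what this exchange does in this assay, so any forecast is uncertain. A modest move towards stronger inhibition is expected, and no large gain. Compound 1, at 8000 nM, shows that a reading within the measurable range is possible in this series. The step is estimated as an at least 1.4-fold lower number from compound 2 to compound 3 (0.15 log units; that floor lies within the scatter). A further reading reported only as a limit would not be a surprise. For compound 3 the expected value is 7000 nM, with an estimated range from 2500 nM to 20000 nM.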

Compound 3, half-maximal inhibitory concentration: 7200 nM
Estimate against measurement, compound 3: 1.0-fold (0.01 log units) below; the range from low to high includes it.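

Setting 1-methylethenyl in place of acetyl on a saturated ring carbon of a four-membered non-aromatic ring of carbon only gives the first step at this position in this assay, with an at least 1.3-fold lower number from compound 2 to compound 3 (0.14 log units; that floor lies within the scatter). That step is only a floor, and the reading for compound 2 is a limit of the assay and not a number: the limit of > 10000 nM in this assay, at which 1 of the 3 values shown sits. At a second site, hydrogen in place of hydroxy on a saturated chain carbon bound to a double-bonded chain carbon gives a 1.1-fold lower number from compound 1 to compound 3 (0.05 log units; within the scatter), so this one pair does not separate the two groups in this assay.

From the compounds shown here alone, the true size of the ring step stays open, since the limit for compound 2 does not say how far its real value lies from that of compound 3. Also open, going by these compounds, is how other groups would read in this assay, such as a carboxylic acid or an amine in place of 1-methylethenyl on the ring carbon, or a methoxy group or an amine in place of hydrogen on the chain carbon.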